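Swapping hydroxymethyl for 3-fluorophenyl on the triazole

A few compounds are considered here, and "the series" means these few. Any claim that something is new, unique, unknown or untested is made for them only; others in the source may bear on it.

Compound 1 `CCCCc1cn(C(c2ccccc2)c2cc3cc(Br)ccc3nc2OC)nn1`: 5.46%
Compound 2 `COc1nc2ccc(Br)cc2cc1C(c1ccccc1)n1cc(-c2ccc(OC(F)(F)F)cc2)nn1`: 11.7%
Compound 3 `COc1nc2ccc(Br)cc2cc1C(c1ccccc1)n1cc(CO)nn1`: 15%

In an ADME assay on PANC-1 cells (Homo sapiens) for cytotoxicity, read by sulforhodamine B assay, with a stated time of 48 h, tested at 10 uM (on this read-out higher numbers stand for more inhibition at the one concentration tested (going by the name of the read-out) and lower numbers for less inhibition), compound 3 gives the highest of the three numbers, yet its steps to compound 2 and compound 1 both fall within the usual scatter, so the three numbers are level with one another. Compound 4 `COc1nc2ccc(Br)cc2cc1C(c1ccccc1)n1cc(-c2cccc(F)c2)nn1` differs from compound 3 as follows: 3-fluorophenyl in place of hydroxymethyl on an aromatic carbon. The closest measured step is a number 3.3 percentage points higher from compound 2 to compound 3 (within the scatter), which runs in the opposite direction, hydroxymethyl in place of 4-(trifluoromethoxy)phenyl, and stayed within the scatter. The step of a number 6.2 percentage points higher from compound 1 to compound 2 (within the scatter), an aromatic group entering on the same ring, likewise stayed within the scatter. Reversing the small change from compound 2 to compound 3, compound 4 is expected to differ from compound 3 by about a number 3 percentage points lower from compound 3 to compound 4 (within the scatter), no more than scatter. Compound 4 is estimated at 12%, between 0% and 25%.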

Compound 4, a percentage reported as inhibition, at one concentration (the size of the read-out at that concentration, not a potency): 15.5%
Compound 4: middle estimate off by 3.5 percentage points, on the low side, within the range that was stated.
By their numbers in this assay, from the lowest: compounds 1, 2, 3 and 4 (each within the scatter of the next).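

In this assay, putting 3-fluorophenyl in place of hydroxymethyl on this aromatic carbon gives a number 0.5 percentage points higher from compound 3 to compound 4 (within the scatter) and so a group with a six-membered aromatic ring and no hydrogen-bond donor reads level with a small one that has a donor. Against the other groups, the same 3-fluorophenyl gives a number 3.8 percentage points higher from compound 2 to compound 4 (within the scatter) and a number 10 percentage points higher from compound 1 to compound 4 (within the scatter) so all four groups at this position read level. Nothing measured here offers an explanation for this flat result. Going by these compounds, whether an amine or a carboxylic acid at this position would move the number beyond the scatter remains open.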